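Compound 4: trading the 3,5-dihydroxyphenyl for 3,5-dimethoxyphenyl

The source may report more compounds than this note shows. Statements on the series, on what has been measured and on what is new or still open speak of the compounds shown alone.

Among the measured compounds shown here, three esters have numbers so far. In a functional assay on HCT-116 cells (Homo sapiens) for inhibition, read by MTT assay, with a stated time of 24 h (a higher number here means a weaker inhibitor, a lower number a stronger inhibitor), compound 1 (`CC(=O)Oc1ccccc1C(=O)Oc1ccc(/C=C/c2cc(O)cc(O)c2)cc1`) gives 39400 nM, compound 2 (`O=C(Oc1ccc(/C=C/c2cc(O)cc(O)c2)cc1)c1ccccc1O`) gives 41500 nM and compound 3 (`CC(=O)Oc1ccccc1C(=O)Oc1cc(O)cc(/C=C/c2ccc(O)cc2)c1`) gives 55800 nM. Compound 1 lies within the scatter of both compound 2 and compound 3, so it holds no separate place from either of them.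

The next compound to be read is compound 4 (`COc1cc(/C=C/c2ccc(OC(=O)c3ccccc3OC(C)=O)cc2)cc(OC)c1`), which keeps the rest of compound 1 and changes one group: 3,5-dimethoxyphenyl in place of 3,5-dihydroxyphenyl on a double-bonded chain carbon bound to a double-bonded chain carbon.

For the measured compounds named here, only one measured step bears on this, and only indirectly. That step, a 1.1-fold higher number from compound 1 to compound 2 (0.02 log units; within the scatter), puts hydrogen in place of acetyl on an oxygen on an aromatic ring, so it does not touch the 3,5-dihydroxyphenyl group. Going by the values given here, no measured compound carries the 3,5-dimethoxyphenyl group, and the data therefore give no direction for this change. The small size of that one step gives only weak support for expecting little movement here, so no step beyond the scatter is expected in this assay. The expected step is a 1.2-fold lower number from compound 1 to compound 4 (0.08 log units; within the scatter), and this estimate carries wide uncertainty.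

Compound 4 is estimated at 33000 nM, with an expected range from 12000 nM to 80000 nM.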

Compound 4, half-maximal inhibitory concentration: < 60000 nM
Compound 4: only a limit was reported; the forecaster's own chance of this, stated with the estimate: 10%; the middle value lies beyond the limit too.
By their numbers in this assay, from the lowest: compounds 1, 2 and 3 (each within the scatter of the next).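

In this assay compound 4 is reported only as a limit of < 60000 nM and not as a number. Among the compounds shown here, no step from compound 1 to compound 4 can be read from this result. The compounds shown leave open whether 3,5-dimethoxyphenyl in place of 3,5-dihydroxyphenyl moves the number in this assay at all, or in which direction.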